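This account rests on a few compounds, and the source may have more. Where it says the series, first, only, none or still open, it means among the compounds named here.

Compound 2 `CC(C)OC(=O)N1CCC(Oc2ncnc3c2CCN3c2ccc(C#N)cc2F)CC1` gives 134% in a functional assay on CHO-K1 cells with Glucose-dependent insulinotropic receptor (Homo sapiens) as the target, read by a luciferase reporter, with a stated time of 5 h (on this read-out lower numbers stand for smaller maximal responses and higher numbers for larger maximal responses), and stands highest of the two numbers in hand; the nearest, compound 1 `CC(C)OC(=O)N1CCC(Oc2ncnc3c2CCN3c2ccc(S(C)(=O)=O)cc2F)CC1`, gives 91% in this assay. Going by the values given here, the one measured step, a number 43 percentage points higher from compound 1 to compound 2 (beyond the scatter), changes the same aromatic carbon that is changed again here. Compound 3 `CC(C)OC(=O)N1CCC(Oc2ncnc3c2CCN3c2ccc(-c3nccs3)cc2F)CC1` differs from compound 2 by 1,3-thiazol-2-yl in place of cyano on an aromatic carbon. That step shows the response can move widely at this carbon, but it offers no direction for an aromatic ring entering in place of cyano. For compound 3 an expected step of a number 19 percentage points lower from compound 2 to compound 3 (beyond the scatter) follows, mildly downward. The estimate for compound 3 is 115%, ranging from 75% to 150%.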

Compound 3, largest response reached (reported as percent of maximum), in percent of the reference or control that the assay uses: 74%
The estimate for compound 3 lay 41 percentage points above the measured number; the measured number lies below the stated range.
By their numbers in this assay, from the lowest: compound 3; then compound 1; then compound 2.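

In this assay 1,3-thiazol-2-yl at the aromatic carbon para to a large group brings a number 60 percentage points lower from compound 2 to compound 3 (beyond the scatter) and also a number 17 percentage points lower from compound 1 to compound 3 (beyond the scatter) and so compound 3 stands lowest of the three. This five-membered aromatic ring therefore does not keep the higher response seen with cyano, nor even the response seen with methylsulfonyl. Nothing available accounts for these differences. Still open, going by these compounds, is how a primary amide or a pyridin-2-yl group would read at this carbon, and whether the same order holds with hydrogen in place of the fluoro group.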